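A longer amine chain on the shared core

The source may hold more compounds than are shown below. What is called first, only, known or untested is meant among the compounds shown, and "the series" means these compounds.

Measured in a functional assay on K562 cells (Homo sapiens) for antiproliferative activity, read by MTT assay, with a stated time of 48 h; a higher number here means a weaker inhibitor, a lower number a stronger inhibitor:
Compound 1 `CCCn1c(N)c(-c2nc3ccccc3[nH]2)c2nc(C#N)c(C#N)nc21`: > 50000 nM (a limit)
Compound 2 `CN(C)CCCn1c(N)c(-c2nc3ccccc3[nH]2)c2nc(C#N)c(C#N)nc21`: 1730 nM

Compound 1 stands at a limit of this assay, not at a number. Going by the values given here, compound 2, at 1730 nM, therefore holds the only true number so far. Compound 3 `CCN(CC)CCCCn1c(N)c(-c2nc3ccccc3[nH]2)c2nc(C#N)c(C#N)nc21` has not yet been measured. It differs from compound 2 by (diethylamino)methyl in place of dimethylamino on a saturated chain carbon, three bonds along the chain from an aromatic nitrogen. Cut one bond further out, the same difference reads 3-(dimethylamino)propyl to 4-(diethylamino)butyl. Among the compounds with values here, the one measured step that bears on this is large: an at least 28-fold lower number from compound 1 to compound 2 (1.46 log units; beyond the scatter). Within the data shown here, it shows what adding the amine did, but no measured step varies the amine or the chain length. Compound 3 keeps an amine on its chain, so the gain in an at least 28-fold lower number from compound 1 to compound 2 (1.46 log units; beyond the scatter) is expected to persist, and no step beyond the scatter is expected in this assay. The expected change is a 1.2-fold lower number from compound 2 to compound 3 (0.06 log units; within the scatter). For compound 3 the estimate is 1500 nM, with an expected range of 500 nM to 5000 nM.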

Compound 3, half-maximal inhibitory concentration: 1440 nM
For compound 3 the middle estimate is 1.0-fold (0.02 log units) above the measured one; low and high end bracket the measured number.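

In this assay, the change from 3-(dimethylamino)propyl to 4-(diethylamino)butyl gives a 1.2-fold lower number from compound 2 to compound 3 (0.08 log units; within the scatter), so a larger amine on a longer chain leaves compound 3 indistinguishable from compound 2. The gain over the chain without an amine is also present with this second amine chain: an at least 34-fold lower number from compound 1 to compound 3 (1.54 log units; beyond the scatter). Compound 1 stands at a limit, > 50000 nM, so that step gives a bound and not an exact size: the limit of > 50000 nM in this assay, at which 1 of the 3 values shown sits.

Compound 3 differs from compound 2 in both the amine and the chain length, and the compounds shown cannot separate these two changes, which could offset each other or each matter little. Going by these compounds, it remains open what a dimethylamino group on the butyl chain, a diethylamino group on the propyl chain, or a morpholine at the chain end would give.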